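The compounds below may be only part of what the source reports. "The series", "measured", "known", "first", "only" and "open" are said of these compounds alone.

Compound 1 `O=Cc1c(-c2ccccc2)nn(-c2ccccc2)c1/N=C/N1CCCCC1` in a functional assay on NPC-TW01 cells (Homo sapiens) for inhibition, read by MTT assay, with a stated time of 72 h (on this read-out higher numbers stand for weaker inhibition of growth and lower numbers for stronger inhibition of growth), gives 24400 nM.
Compound 2 `CN/C=N/c1cc(-c2ccccc2)nn1-c1ccccc1` in this assay gives > 50000 nM, which is a limit of the assay and not a number.

Within the data shown here, compound 2 therefore stands only at the limit of what this assay can report: it sits at the limit of > 50000 nM in this assay, at which 1 of the 2 values shown sits, and compound 1 is the only one of the pair with a measured number. Compound 3 `C/C(=N\c1cc(-c2ccccc2)nn1-c1ccccc1)N(C)C` has not yet been measured. It differs from compound 2 by a group of 6 heavy atoms (4 carbon, 2 nitrogen; no ring) in place of a group of 4 heavy atoms (2 carbon, 2 nitrogen; no ring), on an aromatic carbon, in words: a group of 6 heavy atoms (4 carbon, 2 nitrogen; no ring) in place of a group of 4 heavy atoms (2 carbon, 2 nitrogen; no ring), on an aromatic carbon. Among the measured compounds shown here, no measured step of this kind is known here, so no direction beyond the scatter can be claimed from the data; the change is expected to leave compound 3 close to where compound 2 stands. For compound 3 the expected value in this assay is 45000 nM, with a range from 15000 nM to 100000 nM, meaning an expected step of an at least 1.1-fold lower number from compound 2 to compound 3 (0.04 log units; that floor lies within the scatter).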

Compound 3, concentration for 50% growth inhibition: > 50000 nM
Compound 3 ended at the assay's limit (the forecaster's own chance of this, stated with the estimate: 55%); middle value at least 1.1-fold (0.04 log units) away from the limit.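

Among these compounds, compound 2 and compound 3 both stand at a limit of this assay and not at a number, so no step between them can be read: the limit of > 50000 nM in this assay, at which 2 of the 3 values shown sit.

From the compounds shown here alone, whether swapping the group of 4 heavy atoms for the group of 6 heavy atoms changes growth inhibition at all stays open.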